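The compounds below may be only part of what the source reports. "The series", "measured", "known", "first", "only" and "open" are said of these compounds alone.

Measured compounds in a functional assay on A549 cells (Homo sapiens) for cytotoxicity, read by MTT assay, with a stated time of 72 h; a higher number here means a weaker inhibitor, a lower number a stronger inhibitor:
Compound 1 `O=C1c2c[n+]([O-])c3ccccc3c2C(=O)c2c1c1ccccc1n2Cc1cn(C[C@H](O)CO)nn1` gives 1030 nM.
Compound 2 `CN1CCN(CCCCn2c3c(c4ccccc42)C(=O)c2c[n+]([O-])c4ccccc4c2C3=O)CC1` gives 90 nM.

Going by the values given here, compound 1 has the higher of the two numbers in this assay; the single measured step runs an 11-fold lower number from compound 1 to compound 2 (1.06 log units; beyond the scatter). Compound 3 `O=C1c2c[n+]([O-])c3ccccc3c2C(=O)c2c1c1ccccc1n2Cc1cn(C[C@@H](O)CO)nn1` differs from compound 1 only in configuration: the two compounds have the same atoms and bonds and differ only in configuration as drawn: 1 of 1 stereo elements differ; a stereocentre at a saturated chain carbon is drawn S in compound 1 and R in compound 3. Among the compounds with values here, the measured step concerns a change of substituent, not of configuration, so it offers no guide to this step. With nothing in the data to separate the two configurations, compound 3 is expected to sit close to compound 1, the expected step being no change at the digits printed from compound 1 to compound 3 (within the scatter), within the scatter. The estimate for compound 3 is 1030 nM, in the range 450 nM to 2400 nM.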

Compound 3, half-maximal inhibitory concentration: 390 nM
Compound 3: middle estimate off by 2.6-fold (0.42 log units), on the high side, outside the stated range (below it).
By their numbers in this assay, from the lowest: compound 2; then compound 3; then compound 1.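

In this assay, the stereocentre at a saturated chain carbon proves to matter, with a 2.6-fold lower number from compound 1 to compound 3 (0.42 log units; beyond the scatter) on going from S to R, and this step can be assigned to that stereocentre alone because of one fact: the fact that compounds 1 and 3 differ only in the configuration as drawn. Even drawn R, the 1-(2,3-dihydroxypropyl)-1H-1,2,3-triazol-4-yl group does not match the 3-(4-methylpiperazin-1-yl)propyl group, with a 4.3-fold higher number from compound 2 to compound 3 (0.64 log units; beyond the scatter) remaining. The compounds shown leave open whether the same order of R and S would hold if a primary amine replaced one hydroxyl of the side chain.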